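The source may hold more compounds than are shown below. What is called first, only, known or untested is meant among the compounds shown, and "the series" means these compounds.

Working notes on the series. For the measured compounds named here, in a functional assay on MCF7 cells (Homo sapiens) for antiproliferative activity, read by MTT assay, with a stated time of 72 h (a lower number here means a stronger inhibitor, a higher number a weaker inhibitor), compound 2 (`CCNc1cc(C)c2cc(NC(=O)c3ccc(Cl)c(Cl)c3)ccc2n1`) gives 48600 nM, the highest of the three numbers so far. Compound 1 (`CCN1CCN(c2cc(C)c3cc(NC(=O)c4cccc(C)c4)ccc3n2)CC1`) gives 7800 nM, and compound 3 (`CCN1CCN(c2cc(C)c3cc(NC(=O)c4ccc(Br)cc4)ccc3n2)CC1`) gives 5940 nM.

The next step leads to compound 4 (`Cc1cc(N2CCN(C)CC2)nc2ccc(NC(=O)c3ccc(Cl)c(Cl)c3)cc12`), with one change from compound 2: 4-methylpiperazin-1-yl in place of ethylamino on an aromatic carbon. Going by the values given here, no measured pair isolates this change. Compound 1 and compound 3 both carry a six-membered non-aromatic ring with 2 hetero atoms on that aromatic carbon, with ethyl where compound 4 has methyl. Both sit well under compound 2, but they also differ from it in the group on the carbonyl carbon. Among the compounds with values here, the only measured step, a 1.3-fold lower number from compound 1 to compound 3 (0.12 log units; within the scatter), changes that group and stays within the scatter. The gap to compound 2 may therefore track the ring-bearing substituent, though two compounds are thin support. A lower number in this assay, beyond the scatter, is expected. The expected size is a 5.4-fold lower number from compound 2 to compound 4 (0.73 log units; beyond the scatter). For compound 4 the estimated value is 9000 nM, with an expected range of 3500 nM to 25000 nM.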

Compound 4, half-maximal inhibitory concentration: 3000 nM
Beside the measured number, compound 4's estimate is 3.0-fold (0.48 log units) above it, and the stated range ends above it.
By their numbers in this assay, from the lowest: compounds 4, 3 and 1 (each within the scatter of the next, the first and the last beyond it); then compound 2.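

In this assay, the change at the aromatic carbon next to the ring nitrogen now stands as a single-place comparison with the group on the carbonyl carbon held constant: 4-methylpiperazin-1-yl in place of ethylamino gives a 16-fold lower number from compound 2 to compound 4 (1.21 log units; beyond the scatter). Compound 1 and compound 3 differ from compound 2 in more than one place, so they could only hint at this; this step shows that the change at this position alone is large and beyond the scatter. No measured evidence on hand bears on the reason for this step.

The compounds shown leave open whether the ring itself, its second nitrogen or the methyl on that nitrogen accounts for the step. A morpholine ring or a piperidine ring at this carbon would separate these, and whether the step carries over to other groups on the carbonyl carbon remains unsettled.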